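The source may report more compounds than this note shows. Statements on the series, on what has been measured and on what is new or still open speak of the compounds shown alone.

Series notes. Compound 1 `CC(C(=O)N1CCN(c2ccc(F)cc2)CC1)N1C(=O)CCC1=O` is the reference member of the pair measured so far. In a functional assay on the whole organism (strain Swiss) with Mus musculus as the target, in the maximal electroshock model, with a stated time of 2 h, at a dose of 100 mg/kg by the intraperitoneal route (on this read-out lower numbers stand for a weaker effect and higher numbers for a stronger effect at the one dose given), compound 1 gives 0%. Compound 2 `Cc1cccc(N2CCN(C(=O)C(C)N3C(=O)CCC3=O)CC2)c1` carries 3-methylphenyl in place of 4-fluorophenyl on an amine nitrogen in a ring, and in this assay compound 2 gives 0%. That step reads no change at the digits printed from compound 1 to compound 2 (within the scatter), so compound 2 stands level with compound 1 at the digits recorded, both at the floor of the read-out.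

Compound 3 `CC(C(=O)N1CCN(c2cccc(Cl)c2)CC1)N1C(=O)CCC1=O` is the next member; it differs from compound 2 by chloro in place of methyl on an aromatic carbon. Among the compounds with values here, the only measured step concerns a different exchange on the same amine nitrogen, yet it shows that swapping the aryl group there left the read-out flat, no change at the digits printed from compound 1 to compound 2 (within the scatter). Within the data shown here, no measured step addresses chloro for methyl on an aromatic carbon, so a repeat of the flat result is the expectation rather than a rise. Compound 3 is expected to give about 0%, within 0% to 15%. The expected step is no change at the digits printed from compound 2 to compound 3 (within the scatter), nothing beyond the scatter.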

Compound 3, a percentage reported as activity, at one dose (the size of the read-out at that dose, not a potency): 0%
Compound 3: the middle estimate sits on the measured number at the digits printed; the measured number falls inside the stated range.
By their numbers in this assay, from the lowest: compounds 1, 2 and 3 (each within the scatter of the next).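

In this assay, chloro in place of methyl on an aromatic carbon, meta to a large group, reads no change at the digits printed from compound 2 to compound 3 (within the scatter), which gives this place on the ring a direct reading for one exchange of substituent, something the earlier step could not give. The wider exchange on the amine nitrogen in a ring reads no change at the digits printed from compound 1 to compound 3 (within the scatter), so 4-fluorophenyl, 3-methylphenyl and 3-chlorophenyl now stand level at the floor of the read-out, where these exchanges cannot be told apart. No evidence on hand bears on this flat result.

The compounds shown leave open whether any substituent at this place on the ring can lift the read-out off the floor, for example an amine, a carboxylic acid or a longer chain such as propyl in place of the methyl or chloro. They also leave open whether a benzyl group or a pyridine ring in place of the aryl groups on the amine nitrogen would give any reading in this assay, and with all values at the floor the present set gives no direction for either question.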